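The source may report more compounds than this note shows. Statements on the series, on what has been measured and on what is new or still open speak of the compounds shown alone.

Compound 2 `COc1cc(OC)c2c(=O)cc(-c3ccc(OCc4cn(-c5ccc(Cl)cc5)nn4)c(OC)c3)oc2c1` and compound 1 `COc1cc(OC)c2c(=O)cc(-c3ccc(OCc4cn(-c5ccc(F)cc5F)nn4)c(OC)c3)oc2c1` share one core and part company only in the group carried on the triazole. In an ADME assay on Huh-7 cells (Homo sapiens) for cytotoxicity, read by MTT assay, with a stated time of 72 h (a higher number here means that more compound is tolerated, a lower number that less compound is tolerated), compound 2 gives > 100 ug/mL as a limit of the assay rather than a number. In this assay compound 1 also gives > 100 ug/mL as a limit of the assay rather than a number. The change between them is 2,4-difluorophenyl in place of 4-chlorophenyl on an aromatic nitrogen and the step that the two limits leave unreadable from compound 2 to compound 1 cannot be sized, since both ends are limits. Compound 3 `COc1cc(O)c(C(=O)/C=C/c2ccc(OCc3cn(-c4ccc(Cl)cc4)nn3)c(OC)c2)c(OC)c1` carries the same 4-chlorophenyl triazole on a different core; the difference between the two cores is not broken down here. In this assay compound 3 gives > 100 ug/mL as a limit of the assay rather than a number. Among the compounds with values here, every measured value therefore sits at the limit of > 100 ug/mL in this assay, at which 3 of the 3 values shown sit, and no step among them can be read. Compound 4 `COc1cc(O)c(C(=O)/C=C/c2ccc(OCc3cn(-c4ccc(F)cc4F)nn3)c(OC)c2)c(OC)c1` has not yet been measured. It differs from compound 3 by 2,4-difluorophenyl in place of 4-chlorophenyl on an aromatic nitrogen which is the same change that separates compound 2 from compound 1, at the same place on the triazole. Within the data shown here, because the only measured pair with this change stays at the limit of > 100 ug/mL in this assay, at which 3 of the 3 values shown sit, on both sides, the step from compound 3 to compound 4 is expected to be a step that the limit leaves unreadable from compound 3 to compound 4 and to remain unreadable. Compound 4 is accordingly estimated at 120 ug/mL with a range from 60 ug/mL to 250 ug/mL and is expected to return a limit again.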

Compound 4, half-maximal cytotoxic concentration: > 100 ug/mL
Compound 4 ended at the assay's limit (the forecaster's own chance of this, stated with the estimate: 80%); the middle value is on the limit's open side.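

As far as these compounds go, no new step can be read from compound 4: in this assay compound 3 and compound 4 both give a limit of the assay rather than a number, so the size of the change between them stays unknown: the limit of > 100 ug/mL in this assay, at which 4 of the 4 values shown sit.

The compounds shown leave open at what concentration any of them would become cytotoxic, and whether 2,4-difluorophenyl in place of 4-chlorophenyl, or the difference between the two cores, alters that concentration.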